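The source may report more compounds than this note shows. Statements on the series, on what has been measured and on what is new or still open speak of the compounds shown alone.

Compound 2 `CN(C)CCn1cnnc1-c1cc(Oc2ccc(NC(=O)N/N=C/c3ccccc3)cc2F)ccn1` is the starting point. In a functional assay on U-87MG ATCC cells (Homo sapiens) for cytotoxicity, read by MTT assay, with a stated time of 72 h (on this read-out lower numbers stand for stronger inhibition and higher numbers for weaker inhibition), compound 2 gives 2250 nM, the highest of the two plain numbers measured here, while compound 1 `CN(C)CCn1cnnc1-c1cc(Oc2ccc(NC(=O)N/N=C/c3cc(C(C)(C)C)cc(C(C)(C)C)c3O)cc2F)ccn1` gives 520 nM. Compound 3 `Cn1ncnc1-c1cc(Oc2ccc(NC(=O)N/N=C/c3ccccc3)cc2F)ccn1` reaches only a limit of the assay, > 100000 nM, in this assay; this is the limit of > 100000 nM in this assay, at which 1 of the 3 values shown sits. Going by the values given here, the single step measured in one place, an at least 44-fold higher number from compound 2 to compound 3 (1.64 log units; beyond the scatter), concerns the group on the shared core and not the part changed here. Compound 4 `CN(C)CCn1cnnc1-c1cc(Oc2ccc(NC(=O)N/N=C/c3ccc(F)cc3Cl)cc2F)ccn1` differs from compound 2 in one place: 2-chloro-4-fluorophenyl in place of phenyl on a carbon with a double bond to nitrogen. Among the compounds with values here, no measured step touches this part of the molecule, so nothing measured bears directly on the change; the values of compound 1 and compound 2 show only that a different group in the same place can go with a lower number. The step from compound 2 to compound 4 in this assay is therefore expected to be small and uncertain in direction, the estimated shift being a 1.7-fold lower number from compound 2 to compound 4 (0.24 log units; within the scatter). For compound 4 the expected value in this assay is 1300 nM, within an estimated range of 350 nM to 5000 nM.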

Compound 4, half-maximal inhibitory concentration: 1210 nM
Beside the measured number, compound 4's estimate is 1.1-fold (0.03 log units) above it, and the stated range covers the measured number.
By their numbers in this assay, from the lowest: compound 1; then compounds 4 and 2 (each within the scatter of the next). At a limit, above all of these: compound 3.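

Placing 2-chloro-4-fluorophenyl in place of phenyl on a carbon with a double bond to nitrogen gives, in this assay, a 1.9-fold lower number from compound 2 to compound 4 (0.27 log units; within the scatter). This is the only measured step shown at this part of the molecule, and it shows that chlorine and fluorine can be added to the phenyl ring here while the values of the two compounds remain indistinguishable. Nothing measured here bears on why these two values sit so close.

Going by these compounds, it remains open whether chlorine alone, fluorine alone or either atom elsewhere on the ring would give the same picture. Also open, on these data alone, is whether an amine or a carboxylic acid on this ring would move the number, and which parts of the different group in compound 1, at 520 nM, go with its value.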